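This account rests on a few compounds, and the source may have more. Where it says the series, first, only, none or still open, it means among the compounds named here.

Working notes on the series. Compound 1 `CCN1CCCC(CC(=O)NC2(c3ccc(Cl)c(Cl)c3)C(=O)Nc3cc(Cl)cc(Cl)c32)C1`, compound 2 `CN1CCCN(CC(=O)NC2(c3ccc(Cl)c(Cl)c3)C(=O)Nc3cc(Cl)cc(Cl)c32)CC1` and compound 3 `COc1ccc(C2(NC(=O)CN3CCN(C)CC3)C(=O)Nc3cc(Cl)c(C)cc32)cc1` share a core and have each been tested in an in vitro functional assay on CHO-CREluc cells for antagonist activity at growth hormone secretagogue receptor type 1 (Homo sapiens), read by a luciferase reporter, with a stated time of 4 h; a higher number here means a weaker inhibitor, a lower number a stronger inhibitor. Compound 1 gives 47 nM, compound 2 gives 64 nM and compound 3 gives 525 nM. Compound 2 therefore stands second highest of the three numbers: its nearest neighbour is compound 1, separated by a gap within the scatter, while its gap to compound 3 lies beyond the scatter. Among the compounds with values here, the only single-site step so far, a 1.4-fold higher number from compound 1 to compound 2 (0.13 log units; within the scatter), shows that putting 4-methyl-1,4-diazepan-1-yl in place of 1-ethylpiperidin-3-yl left the number essentially unchanged.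

Compound 4 `CCN1CCC(CC(=O)NC2(c3ccc(Cl)c(Cl)c3)C(=O)Nc3cc(Cl)cc(Cl)c32)CC1` is not yet measured in this assay. Against compound 2 the change is 1-ethylpiperidin-4-yl in place of 4-methyl-1,4-diazepan-1-yl on a saturated chain carbon bound to a carbonyl carbon. The step that bears on this is a 1.4-fold higher number from compound 1 to compound 2 (0.13 log units; within the scatter), which stayed within the scatter when the seven-membered ring was exchanged for a six-membered one; compound 4 carries 1-ethylpiperidin-4-yl, closely related to the group in compound 1, whose value is 47 nM. On that basis compound 4 is expected to show a step of a 1.3-fold lower number from compound 2 to compound 4 (0.11 log units; within the scatter), with no movement beyond the scatter. Compound 4 is estimated at 50 nM in this assay, within a range from 20 nM to 130 nM.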

Compound 4, half-maximal inhibitory concentration: 1 nM
Compound 4: the middle estimate sits 50-fold (1.70 log units) above what was measured; measured number below the stated range.
By their numbers in this assay, from the lowest: compound 4; then compounds 1 and 2 (each within the scatter of the next); then compound 3.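

Within the data shown here, the steep response at this place was hidden by the earlier compounds: in this assay, the only single-site step, a 1.4-fold higher number from compound 1 to compound 2 (0.13 log units; within the scatter), had suggested that the saturated chain carbon bound to a carbonyl carbon tolerated a change of ring. Moving from 1-ethylpiperidin-3-yl to 1-ethylpiperidin-4-yl gives a 47-fold lower number from compound 1 to compound 4 (1.67 log units; beyond the scatter), so the two isomeric ethylpiperidine groups are not interchangeable here, even though they have the same atoms and differ only in how the ring is attached. Replacing 4-methyl-1,4-diazepan-1-yl with 1-ethylpiperidin-4-yl gives a 64-fold lower number from compound 2 to compound 4 (1.81 log units; beyond the scatter), which sets compound 4 apart from both neighbours, and no supporting measurement is available to account for this difference.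

From the compounds shown here alone, it remains open whether the low number depends on the ethyl group, since 1-methylpiperidin-4-yl, 1-isopropylpiperidin-4-yl and the unsubstituted piperidin-4-yl would separate the role of that substituent from the role of the ring attachment. Going by these compounds, it is also open whether 1-ethylpiperidin-4-yl carries the same gain onto the core of compound 3, which differs from compound 4 in more than one place and so cannot be compared with it directly.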